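Hydrogen for Hydroxy on a Weakly Active Ring Core

The compounds below may be only part of what the source reports. "The series", "measured", "known", "first", "only" and "open" are said of these compounds alone.

Compound 1: `COC1=C(O)[C@H](O)[C@H](C/C=C(\C)CC/C=C(\C)C[C@H](O)/C=C(\C)CO)[C@@H](C)C1=O` — > 30000 nM
Compound 2: `COC1=C(OC)[C@H](O)[C@H](C/C=C(\C)CC/C=C(\C)CCC=C(C)C)[C@@H](C)C1=O` — 13500 nM

Of the compounds shown here, two have been measured in a functional assay on PC-3 cells (Homo sapiens) for inhibition, read by sulforhodamine B assay, with a stated time of 48 h; a higher number here means a weaker inhibitor of growth, a lower number a stronger inhibitor of growth. Compound 1 reaches only the limit of the measurement, so its result is not a number: the limit of > 30000 nM in this assay, at which 1 of the 2 values shown sits. Compound 2 does give a number, and in this assay compound 2 shows 13500 nM, which marks it as a weak inhibitor of growth. For the measured compounds named here, no step between the two compounds is worked out, since they differ in more than one place.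

Compound 3, `COC1=C[C@H](O)[C@H](C/C=C(\C)CC/C=C(\C)C[C@H](O)/C=C(\C)CO)[C@@H](C)C1=O`, is the next question. It differs from compound 1 in one place: hydrogen in place of hydroxy on a double-bonded ring carbon.

Going by the values given here, with no measured step to lean on, and compound 1 itself fixed only as a limit, the step of an at least 1.2-fold lower number from compound 1 to compound 3 (0.07 log units; that floor lies within the scatter) is expected to be small, most likely within the usual scatter and in no settled direction. The expectation for compound 3 in this assay is therefore 25000 nM, with a range from 8000 nM to 60000 nM, and a real chance that the assay again reports only a limit.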

Compound 3, concentration for 50% growth inhibition: > 30000 nM
Compound 3: only a limit was reported (the forecaster's own chance of this, stated with the estimate: 45%); at least 1.2-fold (0.07 log units) between middle value and limit.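

Compound 1 and compound 3 both stop at a limit rather than a number, so the step from hydroxy to hydrogen on a double-bonded ring carbon cannot be read: the limit of > 30000 nM in this assay, at which 2 of the 3 values shown sit.

The compounds shown leave open whether this change alters growth inhibition in this assay at all, and in which direction.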